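Shortening the Chlorinated Chain of Compound 2

A few compounds are considered here, and "the series" means these few. Any claim that something is new, unique, unknown or untested is made for them only; others in the source may bear on it.

Among the measured compounds shown here, in a toxicity assay on Huh-7.5 cells (Homo sapiens) for inhibition, read by MTT assay, with a stated time of 96 h (on this read-out higher numbers stand for lower toxicity in this test and lower numbers for higher toxicity in this test), compound 2 `CN1CCN(Cc2ccc(NC(=O)c3ccc(OCCCCCCl)c([N+](=O)[O-])c3)cc2C(F)(F)F)CC1` gives 2140 nM, the lowest of the three numbers measured so far. Compound 1 `CN1CCN(Cc2ccc(NC(=O)c3ccc(OCCCCl)c(F)c3)cc2C(F)(F)F)CC1` stands nearest at 8800 nM, a gap beyond the scatter. Compound 3 `CCC(=O)Nc1cc(C(=O)Nc2ccc(OC)cc2)ccc1OC` lies furthest at 109000 nM, also beyond the scatter.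

Compound 4 `CN1CCN(Cc2ccc(NC(=O)c3ccc(OCCCCl)c([N+](=O)[O-])c3)cc2C(F)(F)F)CC1` has not yet been measured in this assay. It differs from compound 2 in one place: chloro in place of 2-chloroethyl on a saturated chain carbon, three bonds along the chain from an oxygen on an aromatic ring. The same difference can be read as 5-chloropentyl to 3-chloropropyl.

For the measured compounds named here, no measured pair shows this change on its own, so its size cannot be read directly from the data. Compound 2 already holds the lowest number at 2140 nM, and compound 1 is the nearest to it with 8800 nM. A modest rise in this assay is therefore expected, only slightly beyond the scatter, though a result within the scatter would not surprise. The expected change is a 2.1-fold higher number from compound 2 to compound 4 (0.32 log units; beyond the scatter). For compound 4 the estimated value is 4500 nM, with an expected range from 1800 nM to 11000 nM.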

Compound 4, half-maximal cytotoxic concentration: 6800 nM
For compound 4 the middle estimate is 1.5-fold (0.18 log units) below the measured one, within the range that was stated.
By their numbers in this assay, from the lowest: compound 2; then compounds 4 and 1 (each within the scatter of the next); then compound 3.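

In this assay, going from 5-chloropentyl to 3-chloropropyl at this place, three bonds along the chain from an oxygen on an aromatic ring, gives a 3.2-fold higher number from compound 2 to compound 4 (0.50 log units; beyond the scatter) with the nitro group held constant, so the length of the chlorinated chain alone moves the number towards lower toxicity in this test. Among the compounds shown here, with the 3-chloropropyl chain held constant, nitro in place of fluoro on an aromatic carbon gives a 1.3-fold lower number from compound 1 to compound 4 (0.11 log units; within the scatter) and so does not separate the two compounds, which leaves the chain change as the only one of these two steps beyond the scatter. The data shown offer no measurement that would explain either step.

As far as these compounds go, it remains open whether the number keeps rising with a chain shorter than 3-chloropropyl or falls again with one longer than 5-chloropentyl, and whether the chain change has a similar effect with fluoro on the ring. From the compounds shown here alone, it also remains open whether the chlorine itself matters, which a hydroxyl group or an amine at the end of the same chain could test.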